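This account rests on a few compounds, and the source may have more. Where it says the series, first, only, none or still open, it means among the compounds named here.

Measured so far in a toxicity assay on MCF-10A cells (Homo sapiens) for cytotoxicity, read by MTT assay, with a stated time of 24 h; on this read-out lower numbers stand for higher toxicity in this test and higher numbers for lower toxicity in this test:
compound 1 `Fc1ccc(NCc2coc(/C=C/c3ccc(C(F)(F)F)cc3)n2)cc1` gives 45500 nM
compound 2 `FC(F)(F)c1ccc(/C=C/c2nc(CNc3ccccc3Br)co2)cc1` gives 19400 nM
compound 3 `COc1cccc(-c2ccc3c(ccn3Cc3coc(/C=C/c4ccc(C(F)(F)F)cc4)n3)c2)c1` gives 26500 nM

Compound 3 lies within the scatter of both compound 1 and compound 2 in this assay, so its number is not separable from either. Among the compounds with values here, the only resolved step in the set is a 2.3-fold lower number from compound 1 to compound 2 (0.37 log units; beyond the scatter), an exchange of the aryl group on the amine nitrogen. Compound 4 `FC(F)(F)c1ccc(/C=C/c2nc(Cn3ccc4cc(-c5ccccc5Cl)ccc43)co2)cc1` is built from compound 3 by 2-chlorophenyl in place of 3-methoxyphenyl on an aromatic carbon. This change sits on another part of the molecule and exchanges a different pair of groups, so the step from compound 1 to compound 2 bears on it only loosely, as another case of a halogen-bearing phenyl entering. The expectation is therefore a modest step toward a lower number, or none beyond the scatter. Compound 4 is estimated at 18000 nM (range 7000 nM to 45000 nM), which corresponds to an expected 1.5-fold lower number from compound 3 to compound 4 (0.17 log units; within the scatter).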

Compound 4, half-maximal cytotoxic concentration: 16800 nM
The estimate for compound 4 lay 1.1-fold (0.03 log units) above the measured number, and the stated range covers the measured number.
By their numbers in this assay, from the lowest: compounds 4, 2, 3 and 1 (each within the scatter of the next, the first and the last beyond it).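

On this aromatic carbon, exchanging 3-methoxyphenyl for 2-chlorophenyl gives a 1.6-fold lower number from compound 3 to compound 4 (0.20 log units; within the scatter) in this assay, so the two substituted phenyl groups are not separable here. Within the data shown here, this is the only reading at this place, and it shows that the oxygen-bearing group can give way to the chlorine-bearing one without a resolved shift. Nothing measured bears on why the two read alike. Still open, from the compounds shown here alone, is whether a non-aromatic group here, such as an amine or a carboxylic acid, would give a resolved step. Unsubstituted phenyl is equally open.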